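The source may report more compounds than this note shows. Statements on the series, on what has been measured and on what is new or still open speak of the compounds shown alone.

Compound 1, `COc1ccc(-c2[nH]c3ccccc3c2/C=C(\C#N)S(=O)(=O)c2ccccc2)cc1`: 557 nM
Compound 2, `O=C(/C(=C\c1c(-c2ccccc2)[nH]c2ccccc12)S(=O)(=O)c1ccccc1)c1ccccc1`: 5000 nM

In a functional assay on PC-3 cells (Homo sapiens) for inhibition, read by sulforhodamine B assay, with a stated time of 48 h (on this read-out higher numbers stand for weaker inhibition of growth and lower numbers for stronger inhibition of growth), compound 2 gives 5000 nM, the highest of the two numbers measured; compound 1, in the same assay, gives 557 nM, a gap that lies beyond the usual scatter. Compound 3, `N#C/C(=C\c1c(-c2ccccc2)[nH]c2ccccc12)S(=O)(=O)c1ccccc1`, has not been measured. It differs from compound 2 in one place: cyano in place of benzoyl on a double-bonded chain carbon bound to a double-bonded chain carbon and a sulfonyl sulfur. Among the measured compounds shown here, no pair of measured compounds differs in exactly that way, so the step cannot be read directly from the data. For the measured compounds named here, compound 1, which also carries a cyano at that chain carbon, gives 557 nM in this assay, and that is the only guide available. Compound 3 is therefore expected to come out lower than compound 2, with the step from compound 2 to compound 3 estimated at a 6.3-fold lower number from compound 2 to compound 3 (0.80 log units; beyond the scatter). The estimate for compound 3 in this assay is 800 nM, within a range of 300 nM to 2500 nM.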

Compound 3, concentration for 50% growth inhibition: 3400 nM
For compound 3 the middle estimate is 4.3-fold (0.63 log units) below the measured one; measured number above the stated range.
By their numbers in this assay, from the lowest: compound 1; then compounds 3 and 2 (each within the scatter of the next).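

In this assay the exchange of benzoyl for cyano on this chain carbon gives a 1.5-fold lower number from compound 2 to compound 3 (0.17 log units; within the scatter) and so leaves the read-out unmoved, even though cyano has far fewer heavy atoms and no ring. The other new step, hydrogen in place of methoxy on an aromatic carbon, gives a 6.1-fold higher number from compound 1 to compound 3 (0.79 log units; beyond the scatter) and shows that cyano alone does not bring the lower number of compound 1; with cyano held fixed, the methoxy makes the difference. No measurement at hand accounts for either step.

Among the compounds shown here, it remains open whether methoxy would give a similar step with benzoyl on the chain carbon, as it has been seen only with cyano. On these data alone, it also remains open how a carboxylic acid, an amine or a longer alkyl chain would behave on that chain carbon.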